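This account rests on a few compounds, and the source may have more. Where it says the series, first, only, none or still open, it means among the compounds named here.

Among the compounds with values here, compound 3 `Cc1ccc(-c2cs/c(=N/NC(=O)CSc3nnnn3-c3ccccc3)n2-c2ccccc2)cc1` gives 55.1% in a functional assay on C6 cells (Rattus norvegicus) for cytotoxicity, read by MTT assay, with a stated time of 24 h, tested at 12 ug/mL (a higher number here means a weaker effect of the compound at the concentration tested, a lower number a stronger effect), the lowest of the three numbers measured so far. Compound 1 `O=C(CSc1nnnn1-c1ccccc1)N/N=c1/scc(-c2ccc(Br)cc2)n1-c1ccccc1` gives 58.6%, and the step of a number 3.5 percentage points lower from compound 1 to compound 3 (within the scatter) stays within the scatter. Within the data shown here, compound 2 `Cc1nnc(SCC(=O)N/N=c2/scc(-c3ccc(F)cc3)n2-c2ccccc2)s1` gives 73.7%, a number beyond the scatter from compound 3; its core differs from that of compound 3, so no single step joins the two. Compound 4 `O=C(CSc1nnnn1-c1ccccc1)N/N=c1/scc(-c2ccc(F)cc2)n1-c1ccccc1` is reached by one exchange on the same aromatic carbon: fluoro in place of methyl on an aromatic carbon. Among the measured compounds shown here, no measured step covers this exact exchange. For the measured compounds named here, the only step bearing on a swap at that aromatic carbon, a number 3.5 percentage points lower from compound 1 to compound 3 (within the scatter), stayed within the scatter, so the expected step of a number 2.9 percentage points higher from compound 3 to compound 4 (within the scatter) is none beyond the scatter. Compound 4 is therefore estimated at 58%, with a range from 44% to 74%.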

Compound 4, a percentage reported as activity, at one concentration (the size of the read-out at that concentration, not a potency): 60%
The estimate for compound 4 lay 2 percentage points below the measured number; the range from low to high includes it.
By their numbers in this assay, from the lowest: compounds 3, 1 and 4 (each within the scatter of the next); then compound 2.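

In this assay, three groups have now been compared on this aromatic carbon: a number 4.9 percentage points higher from compound 3 to compound 4 (within the scatter) and a number 1.4 percentage points higher from compound 1 to compound 4 (within the scatter) leave methyl, bromo and fluoro unseparated. Neither exchange at this carbon gives a step beyond the scatter. Within the data shown here, with the 4-fluorophenyl group held, the exchange on sulfur of 5-methyl-1,3,4-thiadiazol-2-yl for 1-phenyl-1H-tetrazol-5-yl does exceed it: a number 13.7 percentage points lower from compound 2 to compound 4 (beyond the scatter) is the first single-place step of that size.

Open, on these data alone, is whether an amine or a carboxylic acid on that aromatic carbon would shift the number beyond the scatter, and whether the sulfur exchange gives a similar step with methyl or bromo in place of fluoro. No evidence is available to explain these steps.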